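This account rests on a few compounds, and the source may have more. Where it says the series, first, only, none or still open, it means among the compounds named here.

Measured in a functional assay on RPMI18226 cells (Homo sapiens) for antiproliferative activity, read by sulforhodamine B assay, with a stated time of 48 h, tested at 10 uM; a higher number here means more inhibition at the concentration tested (going by the name of the read-out), a lower number less inhibition:
compound 1 `CN1C/C(=C\c2cccs2)C(=O)[C@@]2(C1)[C@H](c1cccs1)CN(C)[C@]21C(=O)N(C)c2ccccc21` gives 89.4%
compound 2 `COc1ccc(NC(=O)Nc2ccccc2SCCCSc2ccccc2NC(=O)Nc2ccc(OC)cc2)cc1` gives 54.6%
compound 3 `O=C(Nc1ccccc1)c1c(-c2ccc(Cl)cc2)cc(-c2ccccc2)nc1N1CCCCC1` gives 13%

Among these three, compound 3 stands lowest in this assay; compound 2 lies nearest, and its number is higher by a gap beyond the scatter, while compound 1 lies furthest, higher by a still larger gap that is also beyond the scatter. Compound 4 `Cc1ccc(NC(=O)c2c(-c3ccc(Cl)cc3)cc(-c3ccccc3)nc2N2CCCCC2)cc1` differs from compound 3 in one place only: methyl in place of hydrogen on an aromatic carbon. Among the compounds with values here, no pair of measured compounds shows a step of this kind, so the data give no direct guide to its size. Given how small the change is, the step in this assay is expected to be modest and likely none beyond the scatter, with compound 4 estimated at 18% (range 0% to 40%), a step of a number 5 percentage points higher from compound 3 to compound 4 (within the scatter).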

Compound 4, a percentage reported as inhibition, at one concentration (the size of the read-out at that concentration, not a potency): 24%
Beside the measured number, compound 4's estimate is 6 percentage points below it; low and high end bracket the measured number.
By their numbers in this assay, from the lowest: compound 3; then compound 4; then compound 2; then compound 1.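

Going from phenylcarbamoyl to (4-methylphenyl)carbamoyl gives, in this assay, a number 11 percentage points higher from compound 3 to compound 4 (beyond the scatter). Within the data shown here, this is the first step read at this position, and it shows that a single methyl on this six-membered aromatic ring is enough to move the number modestly beyond the usual scatter. Nothing available accounts for the step.

On these data alone, whether an ethyl group, a methoxy group or an amine at the same place would carry the step further stays open. So does whether methyl at another carbon of this ring would have a similar effect.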